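A few compounds are considered here, and "the series" means these few. Any claim that something is new, unique, unknown or untested is made for them only; others in the source may bear on it.

Measured in a functional assay on MDA-MB-231 cells (Homo sapiens) for antiproliferative activity, read by MTT assay, with a stated time of 72 h; a higher number here means a weaker inhibitor, a lower number a stronger inhibitor:
- compound 1 `O=C(CCc1cccc2c1B(O)OC2)Nc1ccccc1`: 230 nM
- compound 2 `C#Cc1cccc(NC(=O)CCc2cccc3c2B(O)OC3)c1`: 1600 nM
- compound 3 `O=C(CCc1cccc2c1B(O)OC2)Nc1cccc(-c2ccccc2)c1`: 220 nM

Compound 3, at 220 nM, shares the low end of these numbers with compound 1, as the record shows a 1.0-fold lower number from compound 1 to compound 3 (0.02 log units; within the scatter). Compound 2 stands apart, with a 7.3-fold lower number from compound 2 to compound 3 (0.86 log units; beyond the scatter).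

The next compound, compound 4 `O=C(CCc1cccc2c1B(O)OC2)Nc1cccc(-c2cccc(Cl)c2)c1`, has chloro in place of hydrogen on an aromatic carbon, turning phenyl into 3-chlorophenyl: chloro in place of hydrogen on an aromatic carbon. Going by the values given here, no measured compound carries chloro, and none carries a substituent on the phenyl of compound 3, so the evidence is indirect. Among the compounds with values here, two steps bear on the change, both replacing hydrogen with another group. Phenyl gave a 1.0-fold lower number from compound 1 to compound 3 (0.02 log units; within the scatter), whereas ethynyl gave a 7.0-fold higher number from compound 1 to compound 2 (0.84 log units; beyond the scatter). The first shows that this assay tolerated a large addition to compound 1, and the second shows that a single change can still move the number modestly. The direction of any shift is therefore unclear, and no step beyond the scatter is expected. The estimate amounts to an expected 1.1-fold higher number from compound 3 to compound 4 (0.06 log units; within the scatter). The estimated value for compound 4 is 250 nM, with an expected range from 90 nM to 700 nM.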

Compound 4, half-maximal inhibitory concentration: 250 nM
For compound 4 middle estimate and measured number coincide at the digits printed, and the stated range covers the measured number.
By their numbers in this assay, from the lowest: compounds 3, 1 and 4 (each within the scatter of the next); then compound 2.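

In this assay, chloro on the phenyl of compound 3 is the only change shown on that outer ring, and it gave a 1.1-fold higher number from compound 3 to compound 4 (0.06 log units; within the scatter), so a chlorine atom at this place, meta to a large group, left the number within the scatter. The 3-chlorophenyl group also gave a 1.1-fold higher number from compound 1 to compound 4 (0.04 log units; within the scatter), which extends the earlier finding for phenyl on compound 1 to a substituted ring, while putting it in place of ethynyl gave a 6.4-fold lower number from compound 2 to compound 4 (0.81 log units; beyond the scatter), leaving compound 2 apart from the other three compounds. Nothing available explains why these numbers fall as they do.

The compounds shown leave open whether this tolerance belongs to chloro alone or extends to other groups on the same ring, such as an amine, a carboxylic acid, a methoxy group or a longer chain. They also leave open whether chloro on another aromatic carbon of that ring would stay within the scatter, and whether a second chloro would do the same.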